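The compounds below may be only part of what the source reports. "The series", "measured", "known", "first", "only" and "open" are said of these compounds alone.

In a functional assay on A2780 cells (Homo sapiens) for antiproliferative activity, read by resazurin assay, with a stated time of 72 h (a lower number here means a stronger inhibitor, a higher number a weaker inhibitor), compound 3 (`Cc1cccc(Cc2n[nH]c3cc(O)c(C(=O)NCc4ccccc4)cc23)c1`) gives > 10000 nM as a limit of the assay and not as a number. That places it at the limit of > 10000 nM in this assay, at which 1 of the 3 values shown sits, in this small series. Two related compounds do return numbers: compound 1 (`CN(Cc1ccccc1)C(=O)c1cc2c(Cc3cccc(F)c3)n[nH]c2cc1O`) reads 1700 nM and compound 2 (`CN(Cc1cccc(NS(C)(=O)=O)c1)C(=O)c1cc2c(Cc3cccc(Cl)c3)n[nH]c2cc1O`) reads 3200 nM in the same test, and neither carries the amide hydrogen that compound 3 has.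

Compound 4 (`Cc1cccc(Cc2n[nH]c3cc(O)c(C(=O)N(C)Cc4ccc(F)cc4)cc23)c1`) differs from compound 3 in one place, with (4-fluorobenzyl)(methyl)amino in place of benzylamino on a carbonyl carbon on the shared core. Like compound 1 at 1700 nM and compound 2 at 3200 nM as well, compound 4 has no amide hydrogen, though this comparison rests on only three compounds and no measured pair isolates the change. A step of an at least 4.0-fold lower number from compound 3 to compound 4 (0.60 log units; beyond the scatter) toward stronger inhibition is therefore expected in this assay and it should lie beyond the usual scatter. For compound 4 the estimated value is 2500 nM with 900 nM to 7000 nM as its expected range.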

Compound 4, half-maximal inhibitory concentration: 590 nM
Beside the measured number, compound 4's estimate is 4.2-fold (0.63 log units) above it; measured number below the stated range.
By their numbers in this assay, from the lowest: compound 4; then compounds 1 and 2 (each within the scatter of the next). At a limit, above all of these: compound 3.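

In this assay, among these compounds, the change on the carbonyl carbon gives an at least 16-fold lower number from compound 3 to compound 4 (1.22 log units; beyond the scatter), the only step that can be read across a single place, and it shows that this position can carry a large difference in antiproliferative activity. The change replaces benzylamino, which counts one hydrogen-bond donor, with (4-fluorobenzyl)(methyl)amino, which counts none, and it also brings in a fluorine, so the step belongs to the swap as a whole and to neither part alone. The reading of compound 3 is a limit of the assay and not a number: the limit of > 10000 nM in this assay, at which 1 of the 4 values shown sits.

On the core of compound 3, a benzyl(methyl)amino group would separate the methyl from the fluorine, and the compounds shown do not make that split. From the compounds shown here alone, whether a (benzyl)(ethyl)amino group or a cyclic amine such as piperidine would hold the same level also stays open.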